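The source may hold more compounds than are shown below. What is called first, only, known or untested is meant among the compounds shown, and "the series" means these compounds.

Working notes on the series. Two compounds carry numbers in a functional assay on HCT-116 cells (Homo sapiens) for cytotoxicity, read by MTT assay, with a stated time of 72 h (a higher number here means a weaker inhibitor, a lower number a stronger inhibitor), so far. Compound 1 `COc1ncc(-c2ccc3nccc(N4CCCC4)c3c2)cc1NS(=O)(=O)c1ccc(F)cc1F` gives 3320 nM in this assay. Within the data shown here, compound 2 `CNCCN(C)Cc1ccc(-c2ccnc3ccc(-c4cnc(OC)c(NS(=O)(=O)c5ccc(F)cc5F)c4)cc23)cc1` gives 51.8 nM in this assay, the lowest of the two numbers; the gap to compound 1 is beyond the scatter, and the two differ in more than one place, so no single step between them is tallied.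

Compound 3 `COc1ncc(-c2ccc3nccc(-c4ccc(Cn5cncn5)cc4)c3c2)cc1NS(=O)(=O)c1ccc(F)cc1F` keeps the core of compound 2 and differs from it in one place: 1H-1,2,4-triazol-1-yl in place of methyl(2-(methylamino)ethyl)amino on a saturated chain carbon bound to an aromatic carbon. Among the measured compounds shown here, no measured pair shows this change, so the size of the step is open. On the two numbers at hand, the expectation is a move toward the weaker side, of moderate size, written as a 5.8-fold higher number from compound 2 to compound 3 (0.76 log units; beyond the scatter). Compound 3 is thus estimated at 300 nM in this assay, with a range of 70 nM to 1500 nM.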

Compound 3, half-maximal inhibitory concentration: 8.7 nM
Compound 3: the middle estimate sits 34-fold (1.54 log units) above what was measured; measured number outside the range, below it.
By their numbers in this assay, from the lowest: compound 3; then compound 2; then compound 1.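

Reading this assay, the methyl(2-(methylamino)ethyl)amino group is not required for a low number at this saturated chain carbon bound to an aromatic carbon: 1H-1,2,4-triazol-1-yl in its place gives a 6.0-fold lower number from compound 2 to compound 3 (0.77 log units; beyond the scatter), so the ring-bearing group is the better of the two here. The wider change on an aromatic carbon, 4-((1H-1,2,4-triazol-1-yl)methyl)phenyl in place of pyrrolidin-1-yl, gives a 380-fold lower number from compound 1 to compound 3 (2.58 log units; beyond the scatter), the larger of the two steps. No measurement at hand speaks to the reason for either step.

From the compounds shown here alone, whether a 1H-imidazol-1-yl or a morpholin-4-yl group on the same carbon would side with compound 3 or with compound 2 remains open. Also open, going by these compounds, is what a carboxylic acid there would do to the number.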